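The compounds below may be only part of what the source reports. "The series", "measured", "known", "first", "only" and "open" are said of these compounds alone.

Compound 1 `Cc1cc(O)c(C(C)C)cc1-c1cc(-c2ccccc2)c(C#N)c(=O)[nH]1`: 29%
Compound 2 `Cc1cc(O)c(C(C)C)cc1-c1cc(-c2ccco2)c(C#N)c(=O)[nH]1`: 42.5%
Compound 3 `COc1ccc(-c2cc(-c3cc(C(C)C)c(O)cc3C)[nH]c(=O)c2C#N)cc1OC`: 44%

In a functional assay for inhibition, tested at 40 ug/mL (on this read-out lower numbers stand for a weaker effect and higher numbers for a stronger effect at the one concentration tested), compound 3 gives the highest of the three numbers, though compound 2 lies within the scatter of it; only compound 1 sits clearly lower. Compound 4 `Cc1cc(O)c(C(C)C)cc1-c1cc(-c2ccccc2[N+](=O)[O-])c(C#N)c(=O)[nH]1` has not yet been measured. It differs from compound 3 in one place: 2-nitrophenyl in place of 3,4-dimethoxyphenyl on an aromatic carbon. Both measured replacements of the phenyl group raised the number beyond the scatter, a number 15 percentage points higher from compound 1 to compound 3 (beyond the scatter) and a number 13.5 percentage points higher from compound 1 to compound 2 (beyond the scatter), while a number 1.5 percentage points higher from compound 2 to compound 3 (within the scatter) did not separate the two substituted rings. For the measured compounds named here, a nitro-bearing ring has no measured precedent here, so the expected step is small: a number 5 percentage points lower from compound 3 to compound 4 (within the scatter). Compound 4 is therefore estimated at 39%, with a range from 26% to 52%.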

Compound 4, a percentage reported as inhibition, at one concentration (the size of the read-out at that concentration, not a potency): 25.5%
Compound 4: the middle estimate sits 13.5 percentage points above what was measured; measured number below the stated range.
By their numbers in this assay, from the lowest: compounds 4 and 1 (each within the scatter of the next); then compounds 2 and 3 (each within the scatter of the next).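

In this assay, a new ring at this position does not always raise the number: 2-nitrophenyl in place of 3,4-dimethoxyphenyl gives a number 18.5 percentage points lower from compound 3 to compound 4 (beyond the scatter) and in place of furan-2-yl gives a number 17 percentage points lower from compound 2 to compound 4 (beyond the scatter) as well. Nitro in place of hydrogen gives a number 3.5 percentage points lower from compound 1 to compound 4 (within the scatter) so, unlike furan-2-yl and 3,4-dimethoxyphenyl, this ring shows no clear gain over plain phenyl. No measurement available here explains this result.

From the compounds shown here alone, it remains open whether an amine or a carboxylic acid in place of the nitro would stay level with phenyl or lift the number.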